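The source may hold more compounds than are shown below. What is called first, only, known or untested is meant among the compounds shown, and "the series" means these compounds.

Compound 1 `FC(F)(F)c1ccc(CN2CCN(Cc3cc(-c4ccc(OCc5ccc(Cl)cc5)cc4)on3)CC2)cc1` was tested in a functional assay on Huh-7 cells (Homo sapiens) for antiproliferative activity, read by sulforhodamine B assay, with a stated time of 72 h (a lower number here means a stronger inhibitor, a higher number a weaker inhibitor), where compound 1 gives 4000 nM. Two related compounds have been measured alongside it. Compound 2 `N#Cc1ccccc1COc1ccc(-c2cc(CN3CCN(Cc4ccc(C(F)(F)F)cc4)CC3)no2)cc1` gives 5000 nM, and compound 3 `COc1ccc(COc2ccc(-c3cc(CN4CCN(Cc5ccc(C(F)(F)F)cc5)CC4)no3)cc2)cc1` gives 3200 nM. Among these three numbers, that of compound 1 is the second highest; its nearest neighbour is compound 2, with a 1.3-fold higher number from compound 1 to compound 2 (0.10 log units; within the scatter), and the furthest is compound 3, with a 1.3-fold lower number from compound 1 to compound 3 (0.10 log units; within the scatter). Since both steps sit within the scatter, none of the three compounds can be called stronger or weaker than another.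

Compound 4 `COc1cc(COc2ccc(-c3cc(CN4CCN(Cc5ccc(C(F)(F)F)cc5)CC4)no3)cc2)cc(OC)c1` has not yet been measured. It differs from compound 1 in one place: 3,5-dimethoxyphenyl in place of 4-chlorophenyl on a saturated chain carbon bound to an oxygen on an aromatic ring. Every step seen so far bears on this change, as each alters the same outer group, on a saturated chain carbon bound to an oxygen on an aromatic ring. Swapping that group entirely gave a 1.6-fold lower number from compound 2 to compound 3 (0.19 log units; within the scatter), and putting methoxy in place of chloro on an aromatic carbon gave a 1.3-fold lower number from compound 1 to compound 3 (0.10 log units; within the scatter). All of these stayed within the scatter. No step beyond the scatter is therefore expected in this assay, only a 1.1-fold lower number from compound 1 to compound 4 (0.06 log units; within the scatter). Compound 4 is estimated at 3500 nM, with a range from 1500 nM to 8000 nM.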

Compound 4, half-maximal inhibitory concentration: 1500 nM
For compound 4 the middle estimate is 2.3-fold (0.37 log units) above the measured one, and the stated range covers the measured number.
By their numbers in this assay, from the lowest: compound 4; then compounds 3, 1 and 2 (each within the scatter of the next).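

The outer group on a saturated chain carbon bound to an oxygen on an aromatic ring had looked unable to move the number in this assay, but 3,5-dimethoxyphenyl shifts it beyond the scatter, with a 2.7-fold lower number from compound 1 to compound 4 (0.43 log units; beyond the scatter) when it replaces 4-chlorophenyl and a 3.3-fold lower number from compound 2 to compound 4 (0.52 log units; beyond the scatter) when it replaces 2-cyanophenyl. The step from the nearest relative, which carries 4-methoxyphenyl, is also beyond the scatter, at a 2.1-fold lower number from compound 3 to compound 4 (0.33 log units; beyond the scatter), so among these four compounds a methoxy group alone does not set compound 4 apart, since compound 3 also has one and stays within the scatter of compound 1 and compound 2; all three steps are modest, but they make compound 4 the strongest of the four. Nothing available here explains why this group gives the lower number.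

Because 3,5-dimethoxyphenyl differs from 4-methoxyphenyl both in how many methoxy groups it carries and in where they sit, these compounds cannot show which of the two differences matters. Nor can they show whether the methoxy groups themselves count, a question that 3,5-dimethylphenyl or 3,5-dichlorophenyl at the same place would address.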